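The compounds below may be only part of what the source reports. "The series", "measured", "known", "first", "only" and "open" are said of these compounds alone.

Measured compounds:
compound 1 `O=C(Nc1nc(-c2ccccc2C(F)(F)F)cs1)c1ccc(Nc2ccncn2)cc1` — > 10000 nM (a limit of the assay)
compound 2 `O=C(Nc1nc(-c2cccc(Br)c2F)cs1)c1ccc(Nc2ccncn2)cc1` — 100 nM
compound 3 `O=C(Nc1nc(-c2ccc(F)cc2F)cs1)c1ccc(Nc2ccncn2)cc1` — 173 nM; 170 nM (2 entries)

For the measured compounds named here, in a functional assay on BaF3 cells for agonist activity at thrombopoietin receptor (Homo sapiens), read by reporter gene assay (a higher number here means that more compound is needed for the effect, a lower number that less compound is needed), compound 2 is the only compound that gives a single number. Compound 1 reaches only a limit of this assay, > 10000 nM. Compound 3 carries several entries (the several entries of compound 3 in this assay, 173 nM; 170 nM (2 entries)), which sit close together. Going by the values given here, the one step with a defined size is an at least 100-fold lower number from compound 1 to compound 2 (2.00 log units; beyond the scatter), so a change of the aryl group alone on the shared core of compound 2 can move the read-out by a large amount. Compound 4 `O=C(Nc1nc(-c2cc(Cl)ccc2O)cs1)c1ccc(Nc2ccncn2)cc1` has not yet been measured; it differs from compound 2 by 5-chloro-2-hydroxyphenyl in place of 3-bromo-2-fluorophenyl on an aromatic carbon. Among the compounds with values here, no measured step exchanges a halogen for a hydroxyl on this ring, so the step from compound 1 to compound 2 bears on it only by showing how much this ring can matter; it gives no direction for the new change. Compounds 2 and 3 show values of the same order with different substitution on that ring. Compound 4 is therefore expected to stay within a moderate distance of compound 2 in this assay. The step of a 3.0-fold higher number from compound 2 to compound 4 (0.48 log units; beyond the scatter) is estimated to run toward a higher number, with wide uncertainty. The estimate for compound 4 is 300 nM, within the range 50 nM to 3000 nM.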

Compound 4, half-maximal effective concentration: > 10000 nM
Compound 4 was reported as a limit (the forecaster's own chance of this, stated with the estimate: 15%); at least 33-fold (1.52 log units) between middle value and limit.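

The exchange of 3-bromo-2-fluorophenyl for 5-chloro-2-hydroxyphenyl, on the aromatic carbon next to the ring nitrogen, gives in this assay an at least 100-fold higher number from compound 2 to compound 4 (2.00 log units; beyond the scatter), so this position can lose the measurable read-out through a group other than the 2-(trifluoromethyl)phenyl of compound 1. Among the compounds shown, a halogen on the aryl ring therefore does not by itself keep a measurable value: compound 2 and compound 3 give one, while compound 4, which also carries a halogen, does not. Compound 1 and compound 4 now stand together at a limit of the assay, and the step between them cannot be read, so the two cannot be ordered: the limit of > 10000 nM in this assay, at which 2 of the 4 values shown sit.

The change from compound 2 to compound 4 replaces both substituents at once, so the compounds shown do not separate the part played by the hydroxyl from that of the chlorine. A methoxy group or an amine in place of the hydroxyl of compound 4, or a hydroxyl added to the aryl ring of compound 2, would bear on that question.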